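Inverting one stereocentre in a trifluoromethyl-bearing urea

The source may report more compounds than this note shows. Statements on the series, on what has been measured and on what is new or still open speak of the compounds shown alone.

Among the measured compounds shown here, in an ADME assay on the whole organism with Oryza sativa as the target, tested at 10 uM (a lower number here means a stronger effect, a higher number a weaker effect of the compound at the concentration tested), compound 3 `C[C@@H](NC(=O)Nc1ccccc1C(F)(F)F)c1ccccc1` gives 54%, the lowest of the three numbers known. Compound 1 `CC(C)c1ccccc1NC(=O)N[C@@H](C)c1ccccc1` gives 93% and compound 2 `C[C@H](NC(=O)Nc1ccccc1C(C)(C)C)c1ccccc1` gives 100%; the step of a number 7 percentage points higher from compound 1 to compound 2 (within the scatter) concerns a methyl in place of hydrogen, not configuration. Compound 4 `C[C@H](NC(=O)Nc1ccccc1C(F)(F)F)c1ccccc1` differs from compound 3 in this way: the two compounds have the same atoms and bonds and differ only in configuration as drawn: 1 of 1 stereo elements differ; a stereocentre at a saturated chain carbon is drawn R in compound 3 and S in compound 4. For the measured compounds named here, no measured pair shows what a change of configuration alone does in this assay, so the expectation rests on compound 3 alone, whose value is 54%. The expected step is a number 6 percentage points higher from compound 3 to compound 4 (within the scatter), with a wide range kept because nothing measured constrains it. Compound 4 is estimated at 60%, between 30% and 95%.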

Compound 4, a percentage reported as activity, at one concentration (the size of the read-out at that concentration, not a potency): 97%
Beside the measured number, compound 4's estimate is 37 percentage points below it; the measured number lies above the stated range.
By their numbers in this assay, from the lowest: compound 3; then compounds 1, 4 and 2 (each within the scatter of the next).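

In this assay, configuration at the saturated chain carbon proves decisive for the trifluoromethyl urea, with a number 43 percentage points higher from compound 3 to compound 4 (beyond the scatter), although no atom or bond changes. In the configuration of compound 4, the aromatic group makes no difference beyond the scatter: a number 4 percentage points higher from compound 1 to compound 4 (within the scatter) and a number 3 percentage points lower from compound 2 to compound 4 (within the scatter). The low number therefore goes with trifluoromethyl and the configuration of compound 3 together, not with trifluoromethyl alone, and the contrast rests on a clean pair: the fact that compounds 3 and 4 differ only in the configuration as drawn

On these data alone, it remains open whether inverting the centre would shift the numbers equally with isopropyl or tert-butyl. As far as these compounds go, it is also open whether a methoxy group or a nitrile in place of trifluoromethyl would keep this dependence on configuration.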